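Removing the trifluoromethyl from the benzamide of compound 1

The compounds below may be only part of what the source reports. "The series", "measured", "known", "first", "only" and "open" are said of these compounds alone.

Compound 1 `COc1cc(-c2nn(-c3cccc(NC(=O)c4cccc(C(F)(F)F)c4)c3)cc2-c2ccncc2)ccc1Cl` carries a trifluoromethyl on the benzamide ring at the end of the molecule. In a functional assay on SK-MEL-2 cells (Homo sapiens) for inhibition, read by sulforhodamine B assay, with a stated time of 48 h (a lower number here means a stronger inhibitor of growth, a higher number a weaker inhibitor of growth), compound 1 gives 1560 nM, the largest of the three numbers measured on this series, though all three lie within the scatter of one another. Compound 2 `O=C(Nc1cccc(-n2cc(-c3ccncc3)c(-c3ccc(Cl)c(O)c3)n2)c1)Nc1cc(C(F)(F)F)cc(C(F)(F)F)c1` gives 1250 nM in this assay, and compound 3 `COc1cc(-c2nn(-c3cccc(NC(=O)Nc4ccc(Cl)c(C(F)(F)F)c4)c3)cc2-c2ccncc2)ccc1Cl` gives 1010 nM.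

Compound 4 `COc1cc(-c2nn(-c3cccc(NC(=O)c4ccccc4)c3)cc2-c2ccncc2)ccc1Cl` is compound 1 with one change: hydrogen in place of trifluoromethyl on an aromatic carbon. For the measured compounds named here, only one measured step touches the same end of the molecule. Going a 1.5-fold lower number from compound 1 to compound 3 (0.19 log units; within the scatter) replaces the benzamide aryl by a substituted anilino urea without moving the number beyond the scatter, which suggests that this terminal ring accepts variation without a large change in growth inhibition. There is, however, no measured step in which the trifluoromethyl is simply removed, so the direction of the effect of the change in compound 4 is not shown by the data.

Taking the tolerance seen in the step to compound 3 as the best guide, compound 4 is expected to give 2500 nM in this assay, in a range from 1000 nM to 6500 nM, which corresponds to an expected step of a 1.6-fold higher number from compound 1 to compound 4 (0.20 log units; within the scatter).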

Compound 4, concentration for 50% growth inhibition: 389 nM
Compound 4: middle estimate off by 6.4-fold (0.81 log units), on the high side; the whole stated range lies above it.
By their numbers in this assay, from the lowest: compound 4; then compounds 3, 2 and 1 (each within the scatter of the next).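

Taking the trifluoromethyl off the benzamide ring gives the first change in this series that lies beyond the scatter: in this assay the step is a 4.0-fold lower number from compound 1 to compound 4 (0.60 log units; beyond the scatter), so at this place, meta to a large group, phenyl gives a lower number than 3-(trifluoromethyl)phenyl. The terminal group therefore does not accept every variation equally, for while the step of a 1.5-fold lower number from compound 1 to compound 3 (0.19 log units; within the scatter) stayed within the scatter, the step of a 2.6-fold lower number from compound 3 to compound 4 (0.41 log units; beyond the scatter) shows benzoyl also going beyond it when it replaces the substituted anilino urea. No measurement among those given accounts for why the number falls when the trifluoromethyl leaves.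

The compounds shown leave open whether hydrogen is specifically required at this place, or whether a fluorine, a methyl, a methoxy or an amine on the same aromatic carbon would keep the number of compound 4. They also leave open whether removing the trifluoromethyl would lower the number in the urea of compound 3 as well, or whether the result holds only for the benzamide.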